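The source may hold more compounds than are shown below. What is called first, only, known or untested is meant among the compounds shown, and "the series" means these compounds.

In a functional assay on cells (Homo sapiens) for cytotoxicity, read by MTT assay, with a stated time of 24 h (on this read-out higher numbers stand for weaker inhibition and lower numbers for stronger inhibition), three compounds sharing one core have been measured. Compound 1 `CCCCCCCCCCCCCCNC(=O)[C@H](CO)/N=C/c1ccc(OC)cc1` gives 28100 nM, compound 2 `CCCCCCCCCCCCCCNC(=O)[C@H](CO)/N=C/c1ccc(O)cc1` gives 19300 nM, and compound 3 `CCCCCCCCCCCCCCNC(=O)[C@H](CO)/N=C/c1ccc([N+](=O)[O-])cc1` gives 217000 nM, the highest number of the three and so the weakest inhibition. Compound 4 `CCCCCCCCCCCCCCNC(=O)[C@H](CO)/N=C/c1ccccc1C` differs from compound 3 by having 2-methylphenyl in place of 4-nitrophenyl on a carbon with a double bond to nitrogen. The nitro compound stands apart: the data show a 7.7-fold higher number from compound 1 to compound 3 (0.89 log units; beyond the scatter) and an 11-fold higher number from compound 2 to compound 3 (1.05 log units; beyond the scatter), while a 1.5-fold lower number from compound 1 to compound 2 (0.16 log units; within the scatter) stays small. Going by the values given here, no measured compound carries 2-methylphenyl, so the comparison is indirect. Compound 4 lacks the nitro group, so a step of similar size back down is expected in this assay, namely a 7.2-fold lower number from compound 3 to compound 4 (0.86 log units; beyond the scatter). Compound 4 is estimated at 30000 nM, with an expected range of 10000 nM to 90000 nM.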

Compound 4, half-maximal inhibitory concentration: 87700 nM
For compound 4 the middle estimate is 2.9-fold (0.47 log units) below the measured one; the measured number falls inside the stated range.
By their numbers in this assay, from the lowest: compounds 2 and 1 (each within the scatter of the next); then compound 4; then compound 3.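

In this assay, 2-methylphenyl lacks the nitro group of 4-nitrophenyl and recovers only part of the gap, with a 2.5-fold lower number from compound 3 to compound 4 (0.39 log units; beyond the scatter). It still stays short of the two oxygen-bearing rings, with a 4.5-fold higher number from compound 2 to compound 4 (0.66 log units; beyond the scatter) and a 3.1-fold higher number from compound 1 to compound 4 (0.49 log units; beyond the scatter), so losing the nitro group does not by itself restore their level at this carbon. Nothing available explains these differences. Open, as far as these compounds go, is where a plain phenyl ring or an aminophenyl ring would fall. Compound 4 changes both the group and its place on the ring, so the two effects cannot yet be separated.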